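The source may hold more compounds than are shown below. What is called first, only, known or untested is meant among the compounds shown, and "the series" means these compounds.

Compound 1 `COc1ccc(-c2nnc(NC(=O)/C=C/c3ccc(F)cc3)s2)cc1` gives 0.75 ug/mL
Compound 2 `Cc1ccc(/C=C/C(=O)Nc2nnc(-c3ccccc3)s2)cc1` gives 1.58 ug/mL

In a functional assay on A549 cells (Homo sapiens) for antiproliferative activity, read by MTT assay, with a stated time of 48 h (on this read-out higher numbers stand for weaker inhibition and lower numbers for stronger inhibition), compound 2 stands highest of the two at 1.58 ug/mL and its gap to compound 1 lies beyond the scatter. Compound 3 `O=C(/C=C/c1ccc(F)cc1)Nc1nnc(-c2ccccc2)s1` comes from compound 2 by the change fluoro in place of methyl on an aromatic carbon with fluoro in place of methyl on an aromatic carbon. For the measured compounds named here, no measured step isolates this change. Compound 1 at 0.75 ug/mL also carries the 4-fluorophenyl, so a small move toward stronger inhibition is expected, with a 1.4-fold lower number from compound 2 to compound 3 (0.16 log units; within the scatter) estimated to stay within the scatter. For compound 3 the estimated value is 1.1 ug/mL with an expected range from 0.45 ug/mL to 2.6 ug/mL on this estimate.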

Compound 3, half-maximal inhibitory concentration: 1.82 ug/mL
Compound 3: middle estimate off by 1.7-fold (0.22 log units), on the low side; the measured number falls inside the stated range.
By their numbers in this assay, from the lowest: compound 1; then compounds 2 and 3 (each within the scatter of the next).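

In this assay, 4-fluorophenyl in place of 4-methylphenyl gives a 1.2-fold higher number from compound 2 to compound 3 (0.06 log units; within the scatter) and so, at this carbon para to a large group, fluoro and methyl cannot be told apart. For the compounds shown here, with the 4-fluorophenyl held fixed, hydrogen in place of methoxy on the other aromatic ring gives a 2.4-fold higher number from compound 1 to compound 3 (0.39 log units; beyond the scatter) and is the only step here beyond the scatter. No evidence accounts for either step.

The compounds shown leave open whether an amine or a carboxylic acid at the para carbon would separate from fluoro and methyl. They also leave open whether a hydroxyl or an ethoxy group would match the methoxy of compound 1.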